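Swapping the aryl group on a thiourea tail

A few compounds are considered here, and "the series" means these few. Any claim that something is new, unique, unknown or untested is made for them only; others in the source may bear on it.

Measured so far in a functional assay on HL-60 cells (Homo sapiens) for inhibition, read by CCK-8 assay, with a stated time of 48 h; a higher number here means a weaker inhibitor, a lower number a stronger inhibitor:
Compound 1 `O=C(NCCNS(=O)(=O)c1ccc(-c2ccccc2Oc2ccc(O)c(O)c2)s1)Nc1cc(Cl)cc(Cl)c1` gives 10400 nM.
Compound 2 `O=C(NCCNS(=O)(=O)c1ccc(-c2ccccc2O[C@H]2CC[C@H](O)CC2)s1)Nc1cc(Cl)cc(Cl)c1` gives only a limit, > 20000 nM.
Compound 3 `O=S(=O)(NCCNC(=S)Nc1ccc(Cl)cc1)c1ccc(-c2ccccc2OCc2ccccc2)s1` gives only a limit, > 50000 nM.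

Compound 3 thus stands among the compounds recorded as a limit rather than a number. Compound 4 `O=[N+]([O-])c1cccc(NC(=S)NCCNS(=O)(=O)c2ccc(-c3ccccc3OCc3ccccc3)s2)c1` differs from it in one place: 3-nitrophenyl in place of 4-chlorophenyl on an amide-type nitrogen. Going by the values given here, the only measured step, an at least 1.9-fold higher number from compound 1 to compound 2 (0.28 log units; that floor lies within the scatter), concerns a different part of the shared core and is itself a floor lying within the scatter, so no measured step bears directly on this change. The expected change in this assay is therefore a number no higher from compound 3 to compound 4 (the limit leaves the size open), that is, none beyond the scatter. Compound 4 is estimated at 50000 nM, with a range from 15000 nM to 150000 nM, and is expected most likely to be reported again only as a limit.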

Compound 4, half-maximal inhibitory concentration: > 50000 nM
Compound 4 gave a limit, no number; the forecaster's own chance of this, stated with the estimate: 80%; the middle value sits exactly at the limit.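

Compound 3 and compound 4 are both recorded only as limits, not as numbers, and the step between them cannot be read. Going by these compounds, how 3-nitrophenyl compares with 4-chlorophenyl on the thiourea tail remains open.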